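Cytotoxicity notes on the oxathiine series: step to compound 4

The source may report more compounds than this note shows. Statements on the series, on what has been measured and on what is new or still open speak of the compounds shown alone.

Measured so far in an ADME assay on HEL cells (Homo sapiens) for cytotoxicity, with a stated time of 3 days; a lower number here means that less compound is tolerated, a higher number that more compound is tolerated:
Compound 1, `CCC1(Cc2ccccc2)OS(=O)(=O)C=C1OCC(=O)OC`: > 400000 nM
Compound 2, `CC(C)C1(Cc2ccccc2)OS(=O)(=O)C=C1OCc1ccccc1`: >= 80000 nM
Compound 3, `CCCC1(Cc2ccccc2)OS(=O)(=O)C=C1OCc1ccccc1`: >= 400000 nM

Compound 1 gives only a limit in this assay, not a number; it sits at the limit of > 400000 nM in this assay, at which 1 of the 3 values shown sits. The value of compound 3 is likewise a limit, (the limit of >= 400000 nM in this assay, at which 1 of the 3 values shown sits). The value of compound 2 is a limit as well, (the limit of >= 80000 nM in this assay, at which 1 of the 3 values shown sits). Among the compounds with values here, no compound in the set has returned a number, so nothing here orders the three against one another. Within the data shown here, the one pair differing in a single place is compound 2 against compound 3: a step that the two limits leave unreadable from compound 2 to compound 3.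

Compound 4, `CCC1(Cc2ccccc2)OS(=O)(=O)C=C1OCC=C(C)C`, differs from compound 1 in one place: 2-methylprop-1-en-1-yl in place of methoxycarbonyl on a saturated chain carbon bound to an oxygen on an unsaturated carbon. Among the measured compounds shown here, no measured step bears on this change; the only step on record concerns the saturated ring carbon, not the chain on the oxygen, and it cannot be read.

Given that compound 1 and its two neighbours all sit at limits of this assay, compound 4 is expected to show the same behaviour, with a tolerated concentration at or near the top of the tested range rather than a readable number. The estimated step from compound 1 to compound 4 is an at least 1.3-fold lower number from compound 1 to compound 4 (0.12 log units; that floor lies within the scatter). For compound 4 the estimate is 300000 nM, within 80000 nM to 400000 nM.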

Compound 4, minimum cytotoxic concentration: 400000 nM
For compound 4 the middle estimate is 1.3-fold (0.12 log units) below the measured one, within the range that was stated.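

In this assay, within the data shown here, compound 4 gives 400000 nM, the first value in the set that is a number and not a limit, so this place on the chain now carries a firm reading. The value of compound 1 remains a limit: the limit of > 400000 nM in this assay, at which 1 of the 4 values shown sits. The change, with methoxycarbonyl leaving and 2-methylprop-1-en-1-yl, which has no hydrogen-bond acceptors, entering, amounts to a number no higher from compound 1 to compound 4 (the limit leaves the size open), so the record fixes its direction only loosely and gives no size for it.

Still open is what a carboxylic acid, an amine or a longer chain would do on the saturated chain carbon bound to an oxygen on an unsaturated carbon, since no compound shown carries any of these there. Also open, on these data alone, is whether 2-methylprop-1-en-1-yl at this place would give a similar reading with propyl or isopropyl in place of the ethyl group on the saturated ring carbon of the core.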